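This account rests on a few compounds, and the source may have more. Where it says the series, first, only, none or still open, it means among the compounds named here.

Compound 1, `O=C1c2ccc(OCc3cccc(-c4ccc(Cl)cc4F)c3)cc2CN1C1CCCC1`, belongs to the same study, but in an assay on HEK293 cells for positive allosteric modulation of metabotropic glutamate receptor 2 (Rattus norvegicus), read by thallium flux (a lower number here means a smaller maximal response, a higher number a larger maximal response), compound 1 gives "not determined" (no result reported), so it gives nothing to compare against. Among the measured compounds shown here, compound 2, `Cn1sc2cc(OCc3cccc(-c4ccc(Cl)c(C(=O)O)c4)c3)ccc2c1=O`, is therefore the only compound with a number: in this assay compound 2 reaches 74.7%. For the measured compounds named here, with a single value there is no measured step and no sense of how much this series moves when one group is swapped for another.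

Compound 3, `O=C(O)c1cc(-c2cccc(COc3ccc4c(=O)n(CC5CC5)sc4c3)c2)ccc1Cl`, has not yet been measured in this assay. It differs from compound 2 in one place: cyclopropyl in place of hydrogen on a saturated chain carbon bound to an aromatic nitrogen. The change adds three carbon atoms in a small ring on the saturated chain carbon bound to the aromatic nitrogen and leaves the acid, the ether and the rest of the core untouched.

Without a measured step to lean on, the expectation for the move a number 3.3 percentage points higher from compound 2 to compound 3 (within the scatter) is a small one, in either direction, and likely within the usual scatter. Compound 3 is expected to give about 78% in this assay, with a plausible range from 55% to 105%.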

Compound 3, largest response reached (reported as percent of maximum), in percent of the reference or control that the assay uses: 38.4%
Compound 3: middle estimate off by 39.6 percentage points, on the high side; measured number outside the range, below it.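

Among the compounds shown here, the first measured step shows that the place on a saturated chain carbon bound to an aromatic nitrogen is not a silent one: cyclopropyl in place of hydrogen there gives a number 36.3 percentage points lower from compound 2 to compound 3 (beyond the scatter) in this assay. Since compound 2 and compound 3 differ in this one place only, the lower maximal response goes with this change and not with the carboxylic acid, the ether or the rest of the shared core, and the step also gives the series its first measure of how far a single swap can move this read-out. Nothing shown explains why the response falls with this change.

The compounds shown leave open whether the lower response goes with the three-membered ring itself or simply with the added carbons, a question that an ethyl group or a longer straight chain at the same place would help to separate. They also leave open whether the step would carry over if the carboxylic acid were replaced by a primary amide, or to a different core such as that of compound 1.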